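Replacing the Pyridin-4-yl Group of Compound 2

The source may report more compounds than this note shows. Statements on the series, on what has been measured and on what is new or still open speak of the compounds shown alone.

Among the measured compounds shown here, in a functional assay (Saphenous vein) with Canis familiaris (Canis lupus familiaris) as the target (on this read-out higher numbers stand for higher potency (the scale is a negative logarithm) and lower numbers for lower potency), two compounds have numbers so far. Compound 1 (`CCOc1ccc(NC(=O)c2ccc(OC)c(CCCN(C)C)c2)cc1`) gives 6.9 in this read-out, while compound 2 (`COc1ccc(NC(=O)c2ccc(-c3ccncc3)cc2)cc1N1CCN(C)CC1`) gives 8 as the higher of the two, a gap beyond the usual scatter.

Compound 3 (`COc1ccc(NC(=O)c2ccc(-c3ccc(C(=O)N(C)C)cc3C)cc2)cc1N1CCN(C)CC1`) keeps the rest of compound 2 but carries 4-(dimethylcarbamoyl)-2-methylphenyl in place of pyridin-4-yl on an aromatic carbon. The new group is much larger than the one it replaces.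

For the measured compounds named here, no measured pair shows what such a swap does, so any forecast here is a judgement from the structures alone. A modest upward step is expected, estimated at a number 0.50 log units higher from compound 2 to compound 3 (beyond the scatter) in size, though a result within the scatter would be no surprise. For compound 3 the estimated value is 8.5 with a likely range from 7.8 to 9.2 on this scale.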

Compound 3, negative logarithm of the antagonist equilibrium constant: 9.2
Compound 3: the middle estimate sits 0.70 log units below what was measured, and the stated range covers the measured number.
By their numbers in this assay, from the lowest: compound 1; then compound 2; then compound 3.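

In this assay, the change brings a large gain, a number 1.20 log units higher from compound 2 to compound 3 (beyond the scatter), showing that this position accepts a much larger group without any loss and can even gain from it. It also shows that high potency in this series does not depend on the ring nitrogen of pyridin-4-yl, since compound 3 carries a ring of carbon only at this place. Nothing measured here explains why the number rises.

Going by these compounds, the change removes the ring nitrogen and adds both a methyl and a dimethylcarbamoyl group in a single step, so the contribution of each remains unknown. Plain phenyl, 2-methylphenyl and 4-(dimethylcarbamoyl)phenyl would be needed to separate these parts, and a carboxylic acid in place of the dimethylcarbamoyl group would test what that part of the group can be.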